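Shortening the amine-bearing amide on the piperidine ring

The source may report more compounds than this note shows. Statements on the series, on what has been measured and on what is new or still open speak of the compounds shown alone.

Measured compounds:
Compound 1 `COc1cc(N)c(Cl)cc1C(=O)NC1CCN(CC2CCN(C(=O)CCCCN)CC2)CC1` — 3.91 nM
Compound 2 `COc1cc(N)c(Cl)cc1C(=O)NC1CCN(CC2CCN(CCCNS(C)(=O)=O)CC2)CC1` — 21.1 nM

Both compounds were tested in an assay on striatum for inhibition of 5-hydroxytryptamine receptor 4 (Cavia porcellus), read by radioligand binding; a lower number here means a stronger inhibitor, a higher number a weaker inhibitor. Compound 1 gives 3.91 nM, and compound 2 gives 21.1 nM. Within the data shown here, of the two numbers, compound 2 stands at the higher one, so it is the weaker inhibitor of the pair; the only measured step is a 5.4-fold higher number from compound 1 to compound 2 (0.73 log units; beyond the scatter), which carries the shared core from an amide bearing a free amine to a sulfonamide-bearing chain.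

Compound 3 `COc1cc(N)c(Cl)cc1C(=O)NC1CCN(CC2CCN(C(=O)C(C)(C)N)CC2)CC1` has not been measured. It differs from compound 2 in one place: (1-amino-1-methylethyl)carbonyl in place of 3-(methanesulfonamido)propyl on an amine nitrogen in a ring. This change returns to a carbonyl bearing a free amine, as found in compound 1, though the chain between them is shorter and carries two methyl groups.

The step from compound 1 to compound 2 is the only one that bears on this, and it was modest in size. Reversing the direction of that step, compound 3 is expected to give a lower number than compound 2, with the expected step of a 3.5-fold lower number from compound 2 to compound 3 (0.55 log units; beyond the scatter). For compound 3 the estimate is 6 nM, within a range of 2 nM to 20 nM, because compound 1 gives 3.91 nM with a related amide.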

Compound 3, half-maximal inhibitory concentration: 2.6 nM
For compound 3 the middle estimate is 2.3-fold (0.36 log units) above the measured one, within the range that was stated.
By their numbers in this assay, from the lowest: compounds 3 and 1 (each within the scatter of the next); then compound 2.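

In this assay, among these compounds, the change on the amine nitrogen in the ring gives an 8.1-fold lower number from compound 2 to compound 3 (0.91 log units; beyond the scatter), so a second carbonyl group bearing a free amine, after the one in compound 1, gives a lower number than the 3-(methanesulfonamido)propyl chain of compound 2. The two amine-bearing groups cannot be told apart here: swapping 4-aminobutyl for 1-amino-1-methylethyl on the carbonyl carbon gives a 1.5-fold lower number from compound 1 to compound 3 (0.18 log units; within the scatter), so this position accepts both the longer straight chain and the shorter one carrying two methyl groups with no readable difference. No measurement at hand explains these numbers.

Still open, from the compounds shown here alone, is whether the free amine itself matters, a question that a carbonyl group carrying a hydroxyl group or a plain alkyl chain in its place would address. Also open, going by these compounds, is whether the higher number of compound 2 goes with its sulfonamide or with the absence of a carbonyl on the ring nitrogen, two features that a simple aminoalkyl chain without a carbonyl, or a carbonyl carrying a methanesulfonamide chain, would separate.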